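The source may hold more compounds than are shown below. What is called first, only, known or untested is meant among the compounds shown, and "the series" means these compounds.

Measured so far in a functional assay on MGC-803 cells (Homo sapiens) for inhibition; on this read-out higher numbers stand for weaker inhibition and lower numbers for stronger inhibition:
- compound 1 `O=C(CC(CC(=O)NC1Cc2ccccc2C1)c1ccc(Cl)cc1)NCCN1CCCC1`: > 100000 nM, a limit
- compound 2 `O=C(CC(CC(=O)NC1Cc2ccccc2C1)c1ccccc1)NCCN1CCCCC1`: > 100000 nM, a limit

Compound 2 has no number of its own in this assay: compound 2 reads > 100000 nM, which is a limit. The whole record so far is the limit of > 100000 nM in this assay, at which 2 of the 2 values shown sit.

The next entry is compound 3 `O=C(CC(CC(=O)NC1Cc2ccccc2C1)c1ccccc1)NCCN1CCCC1`, which has pyrrolidin-1-yl in place of piperidin-1-yl on a saturated chain carbon, two bonds along the chain from an amide-type nitrogen.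

Within the data shown here, no pair of measured compounds gives a step to go by, so the size of this change cannot be read from the series. The expected outcome is a small change: an estimated a number no higher from compound 2 to compound 3 (the limit leaves the size open), with no shift beyond the scatter in either direction. This expectation rests on compound 2, with its limit of > 100000 nM.

For compound 3 the estimate is 100000 nM, with an expected range of 40000 nM to 200000 nM.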

Compound 3, half-maximal inhibitory concentration: > 100000 nM
Compound 3: only a limit was reported; the forecaster's own chance of this, stated with the estimate: 80%; the middle value sits exactly at the limit.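

In this assay compound 3 reads > 100000 nM, a limit. Among these compounds, compound 1, compound 2 and compound 3 all stand as limits, so no step among them can be read, neither from compound 2 to compound 3 nor from compound 1 to compound 3. The compounds shown leave open whether the pyrrolidin-1-yl, piperidin-1-yl or chloro changes alter inhibition at all, the whole record being: the limit of > 100000 nM in this assay, at which 3 of the 3 values shown sit.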